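Chloromethyl to Vinyl on the Amide Carbonyl of Compound 1

This account rests on a few compounds, and the source may have more. Where it says the series, first, only, none or still open, it means among the compounds named here.

Measured compounds:
compound 1, `COc1ccc(CN(C(=O)CCl)c2cc(OC)c(OC)c(OC)c2)cc1O`, 250 nM;
compound 2, `C/C=C/C(=O)N(Cc1ccc(OC)c(Br)c1)c1cc(OC)c(OC)c(OC)c1`, 2800 nM;
compound 3, `COc1ccc(CNc2cc(OC)c(OC)c(OC)c2)cc1[N+](=O)[O-]`, 18200 nM.

The three compounds were tested in a functional assay on HCT-116 cells (Homo sapiens) for inhibition, read by MTT assay, with a stated time of 48 h; on this read-out higher numbers stand for weaker inhibition and lower numbers for stronger inhibition. Compound 1 gives the lowest of the three numbers, with 250 nM. The nearest is compound 2 at 2800 nM, a gap beyond the usual scatter, and the furthest is compound 3 at 18200 nM, also well beyond the scatter. Among the measured compounds shown here, no pair among the measured compounds differs in only one place, so no single-change step is available as a guide.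

Compound 4, `C=CC(=O)N(Cc1ccc(OC)c(O)c1)c1cc(OC)c(OC)c(OC)c1`, is not yet measured. It differs from compound 1 by vinyl in place of chloromethyl on a carbonyl carbon. Compound 2 carries a related group on the same carbonyl and gives a weaker value, but it also differs at the benzyl substituent, so it cannot settle the matter. A modest weakening is expected, and the step of a 2.4-fold higher number from compound 1 to compound 4 (0.38 log units; beyond the scatter) is the estimate for that change. Compound 4 is therefore expected at 600 nM, within 150 nM to 2500 nM.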

Compound 4, half-maximal inhibitory concentration: 98 nM
Compound 4: the middle estimate sits 6.1-fold (0.79 log units) above what was measured, and the stated range ends above it.
By their numbers in this assay, from the lowest: compound 4; then compound 1; then compound 2; then compound 3.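

On the carbonyl carbon whose other neighbour is the amide-type nitrogen, vinyl in place of chloromethyl gives a 2.6-fold lower number from compound 1 to compound 4 (0.41 log units; beyond the scatter) in this assay. Among the compounds shown here, this is the first single-change step, and it shows that chloromethyl is not needed at this position for inhibition in these cells: with vinyl, the number moves lower rather than higher. No measurement shown here accounts for the direction or the size of this step.

Whether the lower number is particular to vinyl stays open, since no other group, such as a simple methyl, an ethynyl group or a longer chain, is shown on this carbonyl with the rest of compound 4 unchanged. Also open, from the compounds shown here alone, is whether the same step would hold with a different substituent on the benzyl group, such as the bromine and methoxy pattern seen elsewhere.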